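The compounds below may be only part of what the source reports. "The series", "measured", "known", "first", "only" and "open" are said of these compounds alone.

In a functional assay on A549 cells (Homo sapiens) for antiproliferative activity, read by MTT assay, with a stated time of 48 h (on this read-out lower numbers stand for stronger inhibition and higher numbers for weaker inhibition), compound 3 `COc1ccc(/C=C/c2cc(OC)cc(OC)c2/C=C/C(=O)c2ccc(Br)cc2)cc1` gives 8.3 ug/mL and lies within the scatter of compound 1 `COc1ccc(/C=C/c2cc(OC)cc(OC)c2/C=C/C(=O)c2ccc(Cl)c(Cl)c2)cc1` at 5.9 ug/mL and apart from compound 2 `COc1ccc(/C=C/c2cc(OC)cc(OC)c2/C=C/C(=O)c2ccc(C)cc2)cc1` at 3.6 ug/mL by a modest margin. Compound 4 `COc1ccc(/C=C/c2cc(OC)cc(OC)c2/C=C/C(=O)c2ccc(C(F)(F)F)cc2)cc1` carries trifluoromethyl in place of bromo on an aromatic carbon in the form of trifluoromethyl in place of bromo on an aromatic carbon, para to a large group. For the measured compounds named here, no measured step covers this exchange, yet the three measured on the same ring bear on it: a 1.4-fold higher number from compound 1 to compound 3 (0.15 log units; within the scatter) and a 1.6-fold lower number from compound 1 to compound 2 (0.21 log units; within the scatter) stay within the scatter, and a 2.3-fold higher number from compound 2 to compound 3 (0.36 log units; beyond the scatter) goes beyond it only modestly. No step beyond the scatter is therefore expected, only a slight drift to a lower number (a 1.4-fold lower number from compound 3 to compound 4 (0.14 log units; within the scatter)). The estimate for compound 4 is 6 ug/mL with 3 ug/mL to 12 ug/mL as its expected range.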

Compound 4, half-maximal inhibitory concentration: 7.8 ug/mL
For compound 4 the middle estimate is 1.3-fold (0.11 log units) below the measured one; low and high end bracket the measured number.
By their numbers in this assay, from the lowest: compounds 2, 1, 4 and 3 (each within the scatter of the next, the first and the last beyond it).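

In this assay, trifluoromethyl and bromo at the position para to a large group cannot be told apart (a 1.1-fold lower number from compound 3 to compound 4 (0.03 log units; within the scatter)). Methyl now stands apart from two groups rather than one (a 2.2-fold higher number from compound 2 to compound 4 (0.34 log units; beyond the scatter)), though only modestly, and compound 1 goes against this separation, as it stays within the scatter of compound 2 while also matching the trifluoromethyl analogue (a 1.3-fold higher number from compound 1 to compound 4 (0.12 log units; within the scatter)). Nothing available explains the gap between methyl and the other two groups.

Going by these compounds, what an amine or a carboxylic acid at this position would do remains open. So does whether the modest gap seen with methyl extends to a longer chain such as propyl.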